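Dimethoxypyrimidine thiourea: expected shift from methylsulfanyl to methoxy

This account rests on a few compounds, and the source may have more. Where it says the series, first, only, none or still open, it means among the compounds named here.

Measured compounds in a functional assay on the whole organism (strain L.) for inhibition, with Echinochloa crus-galli as the target, with a stated time of 72 h, tested at 10 mg/L; on this read-out higher numbers stand for more inhibition of growth at the one concentration tested and lower numbers for less inhibition of growth:
compound 1 `COc1cc(C)nc2n/c(=N/C(=O)c3c(-c4ccc(Cl)cc4Cl)noc3C)sn12` gives 30.9%
compound 2 `COc1cc(SC)nc(NC(=S)NC(=O)c2c(-c3ccc(Cl)cc3Cl)noc2C)n1` gives 19.3%
compound 3 `COc1cc(OC)n2s/c(=N\C(=O)c3c(-c4ccc(Cl)cc4Cl)noc3C)nc2n1` gives 43.2%

Compound 2 stands lowest of the three numbers in this assay; its nearest neighbour is compound 1, and the furthest is compound 3, both gaps lying beyond the scatter. Within the cyclised pair, the step of a number 12.3 percentage points higher from compound 1 to compound 3 (beyond the scatter) is modest but beyond the scatter.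

Compound 4 `COc1cc(OC)nc(NC(=S)NC(=O)c2c(-c3ccc(Cl)cc3Cl)noc2C)n1` has not been measured. It differs from compound 2 in one place: methoxy in place of methylsulfanyl on an aromatic carbon. Among the compounds with values here, no measured step reproduces this exact exchange. Within the data shown here, the only step that bears on it is a number 12.3 percentage points higher from compound 1 to compound 3 (beyond the scatter), which ends at the same dimethoxypyrimidinyl group that compound 4 carries, but starts from methyl rather than methylsulfanyl and sits in the cyclised core rather than the open thiourea of compound 2. It is therefore taken as a loose guide only. A step of similar sign and modest size is expected for compound 4, namely a number 8.7 percentage points higher from compound 2 to compound 4 (within the scatter), with wide uncertainty.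

Compound 4 is thus estimated at 28% in this assay, within a range from 12% to 45%.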

Compound 4, percent growth inhibition at one concentration: 21.8%
Compound 4: middle estimate off by 6.2 percentage points, on the high side; the measured number falls inside the stated range.
By their numbers in this assay, from the lowest: compounds 2, 4 and 1 (each within the scatter of the next, the first and the last beyond it); then compound 3.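

In this assay, the exchange of methylsulfanyl for methoxy on the aromatic carbon next to the ring nitrogen of the open thiourea gives a number 2.5 percentage points higher from compound 2 to compound 4 (within the scatter), so this read-out does not separate the two groups at this position. Carrying the 4,6-dimethoxypyrimidin-2-yl group therefore brings no gain beyond the scatter in the open thiourea, whereas a number 12.3 percentage points higher from compound 1 to compound 3 (beyond the scatter), a step that starts from methyl and belongs to the core of compound 1, is the only change beyond the scatter that ends at methoxy, and it is not a general methoxy effect across these compounds. No measurement available here accounts for this flat result.

From the compounds shown here alone, whether an amine or a chlorine atom on this carbon would move the open thiourea beyond the scatter remains open. Also open, going by these compounds, is how methyl would read on the open thiourea and how methylsulfanyl would read on the core of compound 1, the two exchanges that would show whether this position responds differently in the two frameworks.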